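Biaryl sulfonamide series: methyl on the sulfonyl ring

This account rests on a few compounds, and the source may have more. Where it says the series, first, only, none or still open, it means among the compounds named here.

Measured compounds in a functional assay on J774 cells (Mus musculus) for cytotoxicity, read by resazurin assay, with a stated time of 72 h; a lower number here means a stronger inhibitor, a higher number a weaker inhibitor:
compound 1 `O=S(=O)(Nc1cc(CO)ccc1O)c1ccc(-c2ccc(F)cc2F)cc1`: 200 nM
compound 2 `O=S(=O)(Nc1cccc(CO)c1)c1ccc(-c2ccc(Cl)cc2)cc1`: 2500 nM
compound 3 `O=S(=O)(Nc1cccc(CO)c1)c1ccc(-c2ccc(F)cc2F)cc1`: 300 nM

Compound 3 gives the second highest of the three numbers in this assay. Its nearest neighbour is compound 1, and the gap a 1.5-fold higher number from compound 1 to compound 3 (0.18 log units; within the scatter) lies within the scatter. The furthest is compound 2: the step of an 8.3-fold lower number from compound 2 to compound 3 (0.92 log units; beyond the scatter) is beyond the scatter, so compound 2 stands apart from the other two.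

Compound 4 `Cc1cc(S(=O)(=O)Nc2cccc(CO)c2)ccc1-c1ccc(F)cc1F` differs from compound 3 in one place: methyl in place of hydrogen on an aromatic carbon. Neither measured step touches this position. The step from compound 2 to compound 3 changes the distal aryl group; the step from compound 1 to compound 3 changes the aniline ring. Among the measured compounds shown here, nothing measured so far reports what a methyl on the sulfonyl-bearing ring does in this assay. For the measured compounds named here, with no step that bears on it, the working expectation is a change not beyond the scatter, in either direction, so the estimate for compound 4 is no change at the digits printed from compound 3 to compound 4 (within the scatter).

Compound 4 is therefore expected to give about 300 nM in this assay, with a range from 120 nM to 800 nM reflecting the absence of a directly comparable step.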

Compound 4, half-maximal inhibitory concentration: 100 nM
Beside the measured number, compound 4's estimate is 3.0-fold (0.48 log units) above it; the measured number lies below the stated range.
By their numbers in this assay, from the lowest: compounds 4, 1 and 3 (each within the scatter of the next, the first and the last beyond it); then compound 2.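

In this assay the aromatic carbon ortho to the 2,4-difluorophenyl group now has a reading of its own: methyl in place of hydrogen gives a 3.0-fold lower number from compound 3 to compound 4 (0.48 log units; beyond the scatter) and moves the number toward the stronger end of this assay. The earlier steps shown here changed only the distal aryl group and the aniline ring, so they gave no sign that this carbon responds at all; the new step shows that adding a single carbon here is enough to produce a change beyond the usual scatter, although this rests on one pair of compounds on one background. The data at hand offer no measurement that accounts for the shift.

As far as these compounds go, it remains open whether the response is specific to methyl or extends to other groups at this carbon, such as ethyl, methoxy, chlorine, trifluoromethyl, an amine or a carboxylic acid. From the compounds shown here alone, it is also open whether the same step holds with the 4-chlorophenyl group of compound 2 or the extra hydroxy group on the aniline ring of compound 1.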